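Trifluoromethyl for methoxy on the styryl aryl ring

The source may report more compounds than this note shows. Statements on the series, on what has been measured and on what is new or still open speak of the compounds shown alone.

Measured so far:
compound 1 `COc1cccc(/C=C/C(=O)c2ccc(OC)c3c2OC(C)(C)C=C3)c1` gives > 10000 nM in a functional assay on SW-620 cells (Homo sapiens) for antiproliferative activity, read by MTT assay, with a stated time of 24 h; on this read-out higher numbers stand for weaker inhibition and lower numbers for stronger inhibition
compound 2 `COc1ccc(C(=O)/C=C/c2ccc(Br)cc2)c2c1C=CC(C)(C)O2` gives > 10000 nM in this assay

In this assay compound 1 gives > 10000 nM, which is a limit of the assay and not a number. Compound 2 in this assay likewise gives only a limit, > 10000 nM. The step that the two limits leave unreadable from compound 1 to compound 2 is therefore unreadable, and what the numbers show is summed up in the limit of > 10000 nM in this assay, at which 2 of the 2 values shown sit.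

Compound 3 `COc1ccc(C(=O)/C=C/c2cccc(C(F)(F)F)c2)c2c1C=CC(C)(C)O2` differs from compound 1 by trifluoromethyl in place of methoxy on an aromatic carbon, that is, a trifluoromethyl in place of methoxy on an aromatic carbon, meta to a large group. Among the measured compounds shown here, no measured step bears on this change; the one step on record, a step that the two limits leave unreadable from compound 1 to compound 2, gives no readable size. Because compound 1 sits at the limit of > 10000 nM in this assay, at which 2 of the 2 values shown sit, compound 3 is expected to give 15000 nM in this assay, with a range from 4000 nM to 60000 nM. The estimated step that the limit leaves unreadable from compound 1 to compound 3 means compound 3 is expected most likely to stay at the limit as well.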

Compound 3, half-maximal inhibitory concentration: 7870 nM
Beside the measured number, compound 3's estimate is 1.9-fold (0.28 log units) above it; low and high end bracket the measured number.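

In this assay, trifluoromethyl in place of methoxy on an aromatic carbon, meta to a large group, gives the first value shown that is a number and not a limit of the assay. The change reads as an at least 1.2-fold lower number from compound 1 to compound 3 (0.10 log units; that floor lies within the scatter), so only a floor on the step is known, and that floor does not by itself separate the two compounds. The number for compound 3 therefore stands alone against the remaining values: the limit of > 10000 nM in this assay, at which 2 of the 3 values shown sit.

Going by these compounds, how far compound 1 truly lies from compound 3 stays open, and with it the real size of this step. Also open, on these data alone, is whether an amine or a carboxylic acid on this same aromatic carbon would give a number or stay at the limit.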